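The source may hold more compounds than are shown below. What is called first, only, known or untested is meant among the compounds shown, and "the series" means these compounds.

In a functional assay on COLO 205 cells (Homo sapiens) for antiproliferative activity, read by WST assay, with a stated time of 3 days (on this read-out lower numbers stand for stronger inhibition and higher numbers for weaker inhibition), three compounds have been measured so far, and every result is a limit of the assay rather than a number:

Compound 1 `O=c1cc(I)n([C@@H]2O[C@H](CO)[C@@H](O)[C@H]2O)c(=O)[nH]1` gives > 50000 nM.
Compound 2 `[N-]=[N+]=Nc1cc(=O)[nH]c(=O)n1[C@@H]1O[C@H](CO)[C@@H](O)[C@H]1O` gives > 50000 nM.
Compound 3 `Nc1cc(=O)[nH]c(=O)n1[C@@H]1O[C@H](CO)[C@@H](O)[C@H]1O` gives > 50000 nM.

Compound 3 thus stands at the same limit as the two others; no numerical potency is known for any of the three, and the limit of > 50000 nM in this assay, at which 3 of the 3 values shown sit, is the whole of what the measurements show. The step that the two limits leave unreadable from compound 1 to compound 3 and the step that the two limits leave unreadable from compound 2 to compound 3 are both unreadable in size, and so is a step that the two limits leave unreadable from compound 1 to compound 2.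

Compound 4 `COC(=O)c1cc(=O)[nH]c(=O)n1[C@@H]1O[C@H](CO)[C@@H](O)[C@H]1O` differs from compound 3 in one place: methoxycarbonyl in place of amino on an aromatic carbon. Going by the values given here, none of the measured steps offers a readable size, so this exchange of amino for methoxycarbonyl has nothing in the data to be compared with. What the three measured compounds do show is that three different groups at this position all leave the compound without measurable activity, which makes the same outcome the most reasonable expectation for compound 4. Compound 4 is therefore estimated at 60000 nM, with a range from 20000 nM to 200000 nM, and most probably again only a limit. The step that the limit leaves unreadable from compound 3 to compound 4 is expected to be no step beyond the scatter.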

Compound 4, half-maximal inhibitory concentration: > 50000 nM
Compound 4 ended at the assay's limit; the forecaster's own chance of this, stated with the estimate: 85%; the middle value does not contradict the limit.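

The steps from compound 1, compound 2 and compound 3 to compound 4 cannot be read in size, because all four results are limits, not numbers: the limit of > 50000 nM in this assay, at which 4 of the 4 values shown sit. The compounds shown leave open whether any group at this place on the shared core gives a measurable potency in this assay, and how far these four compounds truly differ.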